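A benzyl group returns to the ring nitrogen

A few compounds are considered here, and "the series" means these few. Any claim that something is new, unique, unknown or untested is made for them only; others in the source may bear on it.

For the measured compounds named here, compound 2 `COc1cc2c(cc1OC)CN(CCCCNC(=O)c1c[nH]nn1)CC2` gives 11000 nM in an assay on membranes from brain for displacement of a labelled ligand from Sigma non-opioid intracellular receptor 1 (Cavia porcellus), read by scintillation counting, with a stated time of 90 min (on this read-out lower numbers stand for stronger inhibition and higher numbers for weaker inhibition), one of only two numbers so far and indistinguishable within the scatter from compound 1 `COc1cc2c(cc1OC)CN(CCCCNC(=O)c1cn(-c3ccccc3OCCF)nn1)CC2`, which in this assay gives 17100 nM. Going by the values given here, the one step recorded between them, a 1.6-fold lower number from compound 1 to compound 2 (0.19 log units; within the scatter), amounts to hydrogen in place of 2-(2-fluoroethoxy)phenyl on an aromatic nitrogen. Compound 3 `COc1ccccc1Cn1cc(C(=O)NCCCCN2CCc3cc(OC)c(OC)cc3C2)nn1` has not yet been measured in this assay. It differs from compound 2 by 2-methoxybenzyl in place of hydrogen on an aromatic nitrogen. Among the compounds with values here, the only measured step that bears on this change is the one between compound 1 and compound 2, in which removing a large group from that same aromatic nitrogen stayed within the scatter, so restoring a large group there is not expected to move the number beyond the scatter. Compound 3 is therefore expected to give 13000 nM in this assay, most likely between 4500 nM and 38000 nM. This estimate means a step of a 1.2-fold higher number from compound 2 to compound 3 (0.07 log units; within the scatter), expected to remain within the scatter.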

Compound 3, inhibition constant: 20600 nM
For compound 3 the middle estimate is 1.6-fold (0.20 log units) below the measured one; measured number inside the range.
By their numbers in this assay, from the lowest: compounds 2, 1 and 3 (each within the scatter of the next).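

On the aromatic nitrogen of the five-membered aromatic ring with 3 nitrogen, 2-methoxybenzyl now stands alongside hydrogen and 2-(2-fluoroethoxy)phenyl, and in this assay the new compound remains within the scatter of both earlier ones (a 1.9-fold higher number from compound 2 to compound 3 (0.27 log units; within the scatter); a 1.2-fold higher number from compound 1 to compound 3 (0.08 log units; within the scatter)). A third substituent at this position, with 9 heavy atoms and a six-membered aromatic ring of carbon only, therefore still gives no step beyond the scatter, and the two large groups cannot be told apart from each other or from hydrogen. Nothing available explains this result.

Going by these compounds, whether an amine or a carboxylic acid carried on this aromatic nitrogen would move the number beyond the scatter remains open. Also open, on these data alone, is whether a longer chain on the ring nitrogen would do so.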